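The source may hold more compounds than are shown below. What is called first, only, known or untested is meant among the compounds shown, and "the series" means these compounds.

Measured compounds:
- compound 1, `CCOC(=O)N1CCC(CN2CC[C@H](NC(=O)c3cc(Cl)c(N)cc3OC)[C@H](OC)C2)CC1`: 377 nM
- compound 2, `COc1cc(N)c(Cl)cc1C(=O)N[C@H]1CCN(CC2CCN(C(=O)CC(C)C)CC2)C[C@H]1OC`: 78 nM
- compound 3, `COc1cc(N)c(Cl)cc1C(=O)N[C@H]1CCN(CCCn2cccc2)C[C@H]1OC`: 648 nM

These three compounds share a core and differ only in the group carried on a saturated chain carbon bound to an amine nitrogen in a ring. In an assay on COS-7 cells for displacement of a labelled ligand from 5-hydroxytryptamine receptor 4 (Homo sapiens), read by scintillation counting, with a stated time of 30 min (a higher number here means a weaker inhibitor, a lower number a stronger inhibitor), compound 3 gives the highest of the three numbers, though its gap to compound 1 is small: a 1.7-fold higher number from compound 1 to compound 3 (0.24 log units; within the scatter). Its gap to compound 2 is larger and beyond the scatter.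

Compound 4, `CCCC(=O)N1CCC(CN2CC[C@H](NC(=O)c3cc(Cl)c(N)cc3OC)[C@H](OC)C2)CC1`, has not yet been measured. It differs from compound 3 by 1-(propylcarbonyl)piperidin-4-yl in place of 2-(1H-pyrrol-1-yl)ethyl on a saturated chain carbon bound to an amine nitrogen in a ring. Among the measured compounds shown here, two measured steps bear on this. Read backwards, a 1.7-fold higher number from compound 1 to compound 3 (0.24 log units; within the scatter) shows that exchanging the pyrrole-bearing chain for an ethoxycarbonyl-capped piperidinyl moves the number only within the scatter. Then a 4.8-fold lower number from compound 1 to compound 2 (0.68 log units; beyond the scatter) shows that replacing ethoxy on that carbonyl carbon with isobutyl gives a modestly lower number. Propyl on the carbonyl carbon resembles the isobutyl of compound 2 more than the ethoxy of compound 1, so a modest step downward is expected in this assay, roughly a 5.0-fold lower number from compound 3 to compound 4 (0.70 log units; beyond the scatter). Compound 4 is therefore estimated at 130 nM, with a likely range from 50 nM to 350 nM.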

Compound 4, half-maximal inhibitory concentration: 178 nM
Compound 4: middle estimate off by 1.4-fold (0.14 log units), on the low side; measured number inside the range.
By their numbers in this assay, from the lowest: compound 2; then compound 4; then compounds 1 and 3 (each within the scatter of the next).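

In this assay, 1-(propylcarbonyl)piperidin-4-yl in place of 2-(1H-pyrrol-1-yl)ethyl gives a 3.6-fold lower number from compound 3 to compound 4 (0.56 log units; beyond the scatter) and so moves the number beyond the scatter, which the ethoxycarbonyl-capped piperidinyl of compound 1 did not do. The group on the carbonyl carbon therefore decides how much this exchange matters: propyl in place of ethoxy gives a 2.1-fold lower number from compound 1 to compound 4 (0.33 log units; beyond the scatter) and shows that isobutyl is not the only carbon chain there to give a lower number than ethoxy. Even a change as small as a methyl counts at this place, since hydrogen in place of methyl on a saturated chain carbon bound to two saturated chain carbons gives a 2.3-fold higher number from compound 2 to compound 4 (0.36 log units; beyond the scatter), but no supporting data are available to explain any of these steps.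

From the compounds shown here alone, it remains open how a longer chain, such as pentyl, or an amine on the carbonyl carbon would compare with propyl and isobutyl. The compounds shown also leave open what the piperidinyl ring does with hydrogen on its nitrogen in place of the carbonyl group.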